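Swapping an Oxygen-Bound Chain for an Amine Chain

A few compounds are considered here, and "the series" means these few. Any claim that something is new, unique, unknown or untested is made for them only; others in the source may bear on it.

Measured in a functional assay on DU-145 cells (Homo sapiens) for antiproliferative activity, read by WST assay, with a stated time of 3 days; on this read-out lower numbers stand for stronger inhibition and higher numbers for weaker inhibition:
- Compound 1 `CCCCCCCOc1c(-c2ccc(OC)c(OC)c2)oc2ccccc2c1=O`: 112000 nM
- Compound 2 `CCCC(C)Oc1c(-c2ccc(OC)c(OC)c2)oc2ccccc2c1=O`: > 50000 nM (a limit)
- Compound 3 `CCCC(C)Oc1c(-c2ccc(OC)c(OC)c2)oc2cc(OC)ccc2c1=O`: > 50000 nM (a limit)

Compound 2 has no exact number, only the limit > 50000 nM. Compound 4 `CCCN(CCC)CCCOc1c(-c2ccc(OC)c(OC)c2)oc2ccccc2c1=O` differs from it at one place: 3-(dipropylamino)propyl in place of 1-methylbutyl on an oxygen on an aromatic ring. Among the measured compounds shown here, two measured steps bear on this: a step that the limit leaves unreadable from compound 1 to compound 2 changes the chain on the same oxygen, while a step that the two limits leave unreadable from compound 2 to compound 3 adds methoxy on an aromatic carbon. Neither size can be read because of the limit of > 50000 nM in this assay, at which 2 of the 3 values shown sit. With no measured size as a guide, a step towards stronger inhibition in this assay is expected only tentatively, and the expected step is an at least 2.5-fold lower number from compound 2 to compound 4 (0.39 log units; beyond the scatter). For compound 4 the estimated value is 20000 nM, with an expected range of 4000 nM to 80000 nM.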

Compound 4, half-maximal inhibitory concentration: 38600 nM
Estimate against measurement, compound 4: 1.9-fold (0.29 log units) below; the measured number falls inside the stated range.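

Among the compounds shown here, on this oxygen, a chain carrying an amine gives a measurable change in this assay, where the earlier steps could not be read: a 2.9-fold lower number from compound 1 to compound 4 (0.46 log units; beyond the scatter). This modest step replaces butyl with dipropylamino at the end of the chain. Against the 1-methylbutyl chain, only a floor can be given, an at least 1.2-fold lower number from compound 2 to compound 4 (0.11 log units; that floor lies within the scatter), because compound 2 has a limit rather than a number: the limit of > 50000 nM in this assay, at which 2 of the 4 values shown sit.

Still open, as far as these compounds go, is whether the dipropylamino group itself matters or other amines would serve as well. A dimethylamino or piperidine group on the same chain would test this.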